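The source may hold more compounds than are shown below. What is called first, only, known or untested is meant among the compounds shown, and "the series" means these compounds.

Measured compounds in an assay on isolated protein for inhibition of Fatty-acid amide hydrolase 1 (Homo sapiens); on this read-out higher numbers stand for weaker inhibition and lower numbers for stronger inhibition:
compound 1, `CCCCCCCC/C=C\CCCCCCC(=O)c1ncc(-c2ccoc2)o1`, gives 610 nM
compound 2, `O=C(CCCCc1ccccc1)c1nc2ncccc2o1`, gives 0.3 nM
compound 3, `CCCCCCCC/C=C\CCCCCCC(=O)c1ccccc1`, is reported only as a limit, > 100000 nM

Compound 3 stands apart from the other two: its result in this assay is not a number but a limit of the measurement, (the limit of > 100000 nM in this assay, at which 1 of the 3 values shown sits), so its inhibition was too weak to be quantified. Compound 4, `CCCCCCCC/C=C\CCCCCCC(=O)c1nc2ccccc2o1`, is not yet measured. It differs from compound 3 in one place, (1,3-benzoxazol-2-yl in place of phenyl on a carbonyl carbon). The two measured compounds that carry an aromatic ring with hetero atoms on the carbonyl carbon both give numbers, compound 1 at 610 nM and compound 2 at 0.3 nM, whereas the plain phenyl ketone of compound 3 gives none. On that ground compound 4 is expected to inhibit far more strongly than compound 3, and the estimated step is an at least 5000-fold lower number from compound 3 to compound 4 (3.69 log units; beyond the scatter). For compound 4 the estimate in this assay is 20 nM, with a likely range from 3 nM to 150 nM.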

Compound 4, inhibition constant: 370 nM
Compound 4: middle estimate off by 19-fold (1.27 log units), on the low side, and the stated range ends below it.
By their numbers in this assay, from the lowest: compound 2; then compounds 4 and 1 (each within the scatter of the next). At a limit, above all of these: compound 3.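

Within the data shown here, compounds 3 and 4 are the first pair here that differ in one place, so they give a direct reading of the group on this carbonyl carbon. In this assay, with the long chain unchanged, 1,3-benzoxazol-2-yl in place of phenyl gives an at least 270-fold lower number from compound 3 to compound 4 (2.43 log units; beyond the scatter), turning a ketone without a measurable value into one with a number. The true size of this step remains unknown because compound 3 is reported only as a limit: the limit of > 100000 nM in this assay, at which 1 of the 4 values shown sits.

The entering group adds a nitrogen, an oxygen and a second ring, and this single change cannot show which of these parts matters. Going by these compounds, how a thiazol-2-yl or pyridin-2-yl group would compare on the same carbonyl carbon remains open, as does whether any ring with hetero atoms there would give a similar step.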